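The compounds below may be only part of what the source reports. "The series", "measured", "known", "first", "only" and "open" are said of these compounds alone.

Of the compounds shown here, three sharing one core have been measured in a functional assay on KM12 cells (Homo sapiens) for inhibition, read by sulforhodamine B assay, with a stated time of 48 h, tested at 10 uM; a lower number here means less inhibition, a higher number more inhibition at the concentration tested (going by the name of the read-out). Compound 1 `Brc1cn2ccnc2c(-c2ccc3ncn(C4CCCCC4)c3c2)n1` gives 67.7% in this assay. Compound 2 `COc1ccc(-c2cn3ccnc3c(-c3ccc4ncn(C5CCCCC5)c4c3)n2)cc1` gives 83.2%, and compound 3 `Fc1ccc(-c2cn3ccnc3c(-c3ccc4ncn(C5CCCCC5)c4c3)n2)cc1` gives 3.49%. Compound 3 stands lowest of the three: the step of a number 64.2 percentage points lower from compound 1 to compound 3 (beyond the scatter) and the step of a number 79.7 percentage points lower from compound 2 to compound 3 (beyond the scatter) are both large and beyond the scatter, whereas a number 15.5 percentage points higher from compound 1 to compound 2 (beyond the scatter) is a modest rise. Compound 4 `c1cn2cc(-c3ccsc3)nc(-c3ccc4ncn(C5CCCCC5)c4c3)c2n1` has not yet been measured. It differs from compound 3 by thiophen-3-yl in place of 4-fluorophenyl on an aromatic carbon. Among the compounds with values here, no measured step exchanges one aromatic group for another of a different ring size at this position; the two steps that do touch it, from bromo to 4-methoxyphenyl and from bromo to 4-fluorophenyl, went in opposite directions and show that the read-out swings strongly with what sits there. The change from 4-fluorophenyl to thiophen-3-yl therefore cannot be anchored to any measured step, and its direction is open. Since compound 3 sits far below the other two, the expectation for compound 4 is placed near the middle of the observed span, so a rise of a number 41.5 percentage points higher from compound 3 to compound 4 (beyond the scatter) is expected. Compound 4 is estimated at 45% in this assay, with a range from 5% to 85%.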

Compound 4, a percentage reported as inhibition, at one concentration (the size of the read-out at that concentration, not a potency): 15.4%
Compound 4: the middle estimate sits 29.6 percentage points above what was measured; the measured number falls inside the stated range.
By their numbers in this assay, from the lowest: compound 3; then compound 4; then compound 1; then compound 2.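

In this assay, two steps now replace a six-membered aromatic ring of carbon only with thiophen-3-yl, and they differ sharply: the exchange for 4-fluorophenyl gives a number 11.9 percentage points higher from compound 3 to compound 4 (beyond the scatter) and is modest, while the exchange for 4-methoxyphenyl gives a number 67.8 percentage points lower from compound 2 to compound 4 (beyond the scatter) and is large. The change of ring alone therefore does not set the level of the read-out at this position, since the outcome depends on which group leaves. Within the data shown here, measured against bromo, thiophen-3-yl gives a number 52.3 percentage points lower from compound 1 to compound 4 (beyond the scatter) and so falls on the same side as 4-fluorophenyl, which makes compound 2 the one compound among those carrying an aromatic ring here that goes against a large loss relative to bromo.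

Nothing shown explains why 4-methoxyphenyl stands apart from the other two aromatic groups at this position. Going by these compounds, it remains open whether other groups at this position, such as an amine, a carboxylic acid or a longer chain, or a methoxy group on the thiophene ring, would give a read-out nearer that of compound 2 or that of compound 3.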